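Series notes: aryl ketone change, compound 2 to compound 4

The compounds below may be only part of what the source reports. "The series", "measured", "known", "first", "only" and "open" are said of these compounds alone.

Three compounds carry measurements in a functional assay on HeLa cells (Homo sapiens) for antiproliferative activity, read by sulforhodamine B assay, with a stated time of 48 h; a lower number here means a stronger inhibitor, a higher number a weaker inhibitor. Compound 1 `COc1cc(C(=O)/C=C\Nc2ccc(-c3nc4cc(OC)c(OC)c(OC)c4s3)cc2C)cc(OC)c1OC` gives 11100 nM. Compound 2 `COc1cc(OC)c2sc(-c3ccc(N/C=C\C(=O)c4ccc(OC)c(F)c4)c(C)c3)nc2c1` gives 14700 nM, the highest of the three numbers; its nearest neighbour is compound 1 and its furthest is compound 3, and neither gap goes beyond the scatter. Compound 3 `COc1cc(OC)c2sc(-c3ccc(N/C=C\C(=O)c4ccc(OC)c(F)c4)cc3)nc2c1` gives 7300 nM. Among the compounds with values here, the only step between compounds that differ in one place is a 2.0-fold lower number from compound 2 to compound 3 (0.30 log units; within the scatter), hydrogen in place of methyl on an aromatic carbon, and it stays within the scatter.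

Compound 4 `COc1cc(OC)c2sc(-c3ccc(N/C=C\C(=O)c4cc(OC)c(OC)c(OC)c4)c(C)c3)nc2c1` is not yet measured. Compared with compound 2 it shows (3,4,5-trimethoxyphenyl in place of 3-fluoro-4-methoxyphenyl on a carbonyl carbon). Within the data shown here, no measured step bears directly on this exchange: the step from compound 2 to compound 3 concerns a different site, and compound 1, which also carries a trimethoxyphenyl on the carbonyl carbon, differs from compound 2 in more than one place, so no step is computed between them. Only the two values can be set side by side: compound 1 gives 11100 nM and compound 2 gives 14700 nM, and these are close to each other.

On that basis no step beyond the scatter is expected in this assay. Compound 4 is expected to give about 10000 nM, with a range of 3500 nM to 28000 nM. The expected step of a 1.5-fold lower number from compound 2 to compound 4 (0.17 log units; within the scatter) would stay within the scatter.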

Compound 4, half-maximal inhibitory concentration: 16400 nM
For compound 4 the middle estimate is 1.6-fold (0.21 log units) below the measured one, and the stated range covers the measured number.
By their numbers in this assay, from the lowest: compounds 3, 1, 2 and 4 (each within the scatter of the next, the first and the last beyond it).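

In this assay, 3,4,5-trimethoxyphenyl in place of 3-fluoro-4-methoxyphenyl on a carbonyl carbon gives a 1.1-fold higher number from compound 2 to compound 4 (0.05 log units; within the scatter), so this site now has a direct reading: the exchange from 9 to 12 heavy atoms and from 1 to 3 hydrogen-bond acceptors leaves the number within the scatter. Within the data shown here, compound 4 also gives the first step with the trimethoxyphenyl ketone held constant, a 1.5-fold higher number from compound 1 to compound 4 (0.17 log units; within the scatter), and this too stays within the scatter, so neither change separates its pair in this assay. No data on the compounds bear on what lies behind these numbers.

Among these compounds, the carbonyl carbon is covered here by only two aryl groups, both methoxy-bearing, so it remains open whether a phenyl ring carrying an amine or a carboxylic acid at this place would give a step beyond the scatter. On these data alone, the exchange of methyl for hydrogen is read only with 3-fluoro-4-methoxyphenyl on the carbonyl carbon, and its reading with 3,4,5-trimethoxyphenyl there also remains open.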